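Fluoro for methyl on the anilide of compound 2

This account rests on a few compounds, and the source may have more. Where it says the series, first, only, none or still open, it means among the compounds named here.

Compound 2 `Cc1ccc(NC(=O)CCc2cn(Cc3ccc4oc(-c5ccccc5)cc(=O)c4c3)nn2)cc1` is the reference point. In an assay on isolated protein for inhibition of Amine oxidase [flavin-containing] B (Homo sapiens), read by fluorescence and spectrophotometry (on this read-out lower numbers stand for stronger inhibition and higher numbers for weaker inhibition), compound 2 gives 15600 nM, the lowest number of the three measured; compound 3 `Cc1ccc(NC(=O)CCc2cn(Cc3ccc4oc(-c5ccc(Cl)cc5)cc(=O)c4c3)nn2)cc1` gives 32900 nM and compound 1 `Cc1ccc(NC(=O)CCCCc2cn(Cc3ccc4oc(-c5ccc(Cl)cc5)cc(=O)c4c3)nn2)cc1` gives 32900 nM, and each of these lies one step above compound 2 beyond the scatter. The measured steps are a 2.1-fold higher number from compound 2 to compound 3 (0.32 log units; beyond the scatter) and no change at the digits printed from compound 1 to compound 3 (within the scatter). Neither touches the anilide end of the molecule: one concerns the ring at the far end of the shared core, the other the chain linking the triazole to the amide.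

Compound 4 `O=C(CCc1cn(Cc2ccc3oc(-c4ccccc4)cc(=O)c3c2)nn1)Nc1ccc(F)cc1` differs from compound 2 by fluoro in place of methyl on an aromatic carbon. For the measured compounds named here, no measured step bears directly on this change, so there is nothing to argue for a move in either direction; the anilide has so far been held constant, and the only steps known, a 2.1-fold higher number from compound 2 to compound 3 (0.32 log units; beyond the scatter) on another ring and no change at the digits printed from compound 1 to compound 3 (within the scatter) on the chain, are modest or absent. The expectation is therefore no step beyond the scatter, with a slight lean toward a higher number as the more common outcome in this set: compound 4 is estimated at 19000 nM, range 7000 nM to 50000 nM. This estimate corresponds to an expected step of a 1.2-fold higher number from compound 2 to compound 4 (0.09 log units; within the scatter).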

Compound 4, half-maximal inhibitory concentration: 15600 nM
Beside the measured number, compound 4's estimate is 1.2-fold (0.09 log units) above it, and the stated range covers the measured number.
By their numbers in this assay, from the lowest: compounds 2 and 4 (each within the scatter of the next); then compounds 1 and 3 (each within the scatter of the next).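

The anilide end, constant across compounds 1 to 3, now has a measured change of its own: in this assay the step is no change at the digits printed from compound 2 to compound 4 (within the scatter) on this ring, so 4-methylphenyl and 4-fluorophenyl cannot be told apart here, at the aromatic carbon para to a large group. For the compounds shown here, the only step beyond the scatter among the single changes remains a 2.1-fold higher number from compound 2 to compound 3 (0.32 log units; beyond the scatter) at the other end of the molecule, where chloro stands in place of hydrogen, and the exchange of methyl for fluoro adds no second such step. Nothing in hand accounts for the two groups giving matching numbers in this series.

Going by these compounds, whether this position is as flat for other groups stays open, since an amine, a carboxylic acid or a methoxy group on the anilide ring could still separate from methyl and fluoro. Also open, on these data alone, is whether the 4-fluorophenyl amide keeps level with its 4-methylphenyl partner when paired with the 4-chlorophenyl variant of the core or with the longer chain of compound 1.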